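This account rests on a few compounds, and the source may have more. Where it says the series, first, only, none or still open, it means among the compounds named here.

Measured compounds:
Compound 1 `CNC(=O)c1cnc(N2CCN(C3CCN(Cc4ccc(C)cc4)CC3)[C@@H](C)C2)c(Cl)c1`: 87 nM in a functional assay for antagonist activity at C-X-C chemokine receptor type 3 (Homo sapiens); on this read-out higher numbers stand for weaker inhibition and lower numbers for stronger inhibition
Compound 2 `CNC(=O)c1cnc(N2CCN(C3CCN(C(F)(F)F)CC3)[C@@H](C)C2)c(Cl)c1`: 63 nM

Of the two numbers shown, compound 1 stands at the higher one, but its only neighbour, compound 2, sits close by: the step of a 1.4-fold lower number from compound 1 to compound 2 (0.14 log units; within the scatter), so the two cannot be told apart. Compound 3 `CNC(=O)c1cnc(N2CCN(C3CCN(C(=O)c4ccc(Cl)cc4)CC3)[C@@H](C)C2)c(Cl)c1` has not yet been measured. Its change from compound 1 is (4-chlorophenyl)carbonyl in place of 4-methylbenzyl on an amine nitrogen in a ring. Within the data shown here, the one measured step that bears on this is the one from compound 1 to compound 2, in which the same amine nitrogen in a ring carried a quite different group and the number moved only within the scatter. That gives little ground to expect a large shift in this assay ; the estimated step is a 1.1-fold higher number from compound 1 to compound 3 (0.06 log units; within the scatter), with no clear direction. Compound 3 is therefore expected to give about 100 nM in this assay , within a range from 35 nM to 300 nM.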

Compound 3, half-maximal inhibitory concentration: 210 nM
The estimate for compound 3 lay 2.1-fold (0.32 log units) below the measured number, and the stated range covers the measured number.
By their numbers in this assay, from the lowest: compounds 2 and 1 (each within the scatter of the next); then compound 3.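

In this assay, the amine nitrogen in a ring now proves not to be indifferent to what it carries: the swap of 4-methylbenzyl for (4-chlorophenyl)carbonyl gives a 2.4-fold higher number from compound 1 to compound 3 (0.38 log units; beyond the scatter), although the earlier change at this nitrogen stayed within the scatter. Set against trifluoromethyl at the same nitrogen, the same group gives a 3.3-fold higher number from compound 2 to compound 3 (0.52 log units; beyond the scatter), so both measured neighbours show stronger inhibition than compound 3, though only modestly. Nothing measured here explains why the number rose.

Compound 3 differs from compound 1 both in the carbonyl and in the chlorine, so the compounds shown cannot say which of the two goes with the step. A chlorobenzyl group, which keeps the chlorine without the carbonyl, and a plain benzoyl group, which keeps the carbonyl without the chlorine, would separate them.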